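The compounds below may be only part of what the source reports. "The series", "measured", "known", "first", "only" and "open" are said of these compounds alone.

The measured compounds are compound 1 `Cc1cn(Cc2cc(Br)ccc2OCc2ccccc2)nc1C(=O)O` with 427 nM, compound 2 `O=C(O)c1nn(Cc2cc(Br)ccc2OCc2ccccc2)cc1C(F)(F)F` with 2570 nM, and compound 3 `Cc1cccc(COc2ccc(Br)cc2Cn2nc(C(=O)O)cc2C)c1` with 126 nM, all in an assay on CHO-K1 cells for displacement of a labelled ligand from prostaglandin E2 receptor EP1 subtype (Homo sapiens); a higher number here means a weaker inhibitor, a lower number a stronger inhibitor.

Compound 4 `Cc1cc(C(=O)O)nn1Cc1cc(Br)ccc1OCc1cccc(C(F)(F)F)c1` has not been measured. It differs from compound 3 by trifluoromethyl in place of methyl on an aromatic carbon. The same kind of change was made from compound 1 to compound 2, where it is trifluoromethyl in place of methyl on an aromatic carbon, and there it gave a 6.0-fold higher number from compound 1 to compound 2 (0.78 log units; beyond the scatter). The two places are not the same: in the step from compound 1 to compound 2 the change sits on a five-membered aromatic ring with 2 nitrogen, next to the ring atom that bears a carboxy group, whereas in the step from compound 3 to compound 4 it sits on a six-membered aromatic ring of carbon only, meta to a large group. The difference between the core of compound 1 and the core of compound 3 is not broken down here.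

Going by the values given here, for compound 4 the expectation rests on the single earlier step of a 6.0-fold higher number from compound 1 to compound 2 (0.78 log units; beyond the scatter), made at another place, so only a weaker echo of that rise is expected, estimated as a 2.4-fold higher number from compound 3 to compound 4 (0.38 log units; beyond the scatter). Compound 4 is therefore expected to give about 300 nM in this assay, between 90 nM and 1000 nM.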

Compound 4, half-maximal inhibitory concentration: 309 nM
For compound 4 the middle estimate is 1.0-fold (0.01 log units) below the measured one; the measured number falls inside the stated range.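

In this assay, trifluoromethyl in place of methyl again gives a weaker inhibitor, this time on a six-membered aromatic ring of carbon only, with a 2.5-fold higher number from compound 3 to compound 4 (0.39 log units; beyond the scatter). Set side by side, the two steps run in the same direction, and their sizes cannot be told apart: the same change on two cores in this assay, a 6.0-fold higher number (0.78 log units; beyond the scatter) from compound 1 to compound 2 and a 2.5-fold higher number (0.39 log units; beyond the scatter) from compound 3 to compound 4, 2.5-fold (0.39 log units) apart, within the scatter of two such steps

This shows that the direction of the change held in both of these pairs, but two pairs are a thin basis for a rule, and the change sits at a different place in each, so the effect of the core alone cannot be separated from the effect of the place.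

The compounds shown leave open how a chlorine atom, a methoxy group or a nitrile would compare with methyl and trifluoromethyl on the six-membered aromatic ring of carbon only. They also leave open whether a plain hydrogen there would give a stronger or a weaker inhibitor than either group.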